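The compounds below may be only part of what the source reports. "The series", "measured", "known", "first", "only" and "open" are said of these compounds alone.

Measured compounds:
compound 1 `COC(=O)C1=C(C)N=C(C)/C(=C(\O)OC)C1c1ccc(Cl)cc1` — 8130 nM
compound 2 `COC(=O)C1=C(C)N=C(C)/C(=C(\O)OC)C1c1cc(Cl)cc(Cl)c1` — 93.3 nM
compound 3 `COC(=O)C1=C(C)N=C(C)/C(=C(\O)OC)C1c1ccc(F)cc1` — 129 nM

In a functional assay (muscle tissue) with Cavia porcellus as the target (on this read-out lower numbers stand for an effect already at smaller amounts and higher numbers for an effect only at larger amounts of compound), compound 1 stands highest of the three, with compound 3 nearest and compound 2 furthest. Compound 4 `COC(=O)C1=C(C)N=C(C)/C(=C(\O)OC)C1c1c(Cl)cccc1Cl` is not yet measured; it differs from compound 1 thus: 2,6-dichlorophenyl in place of 4-chlorophenyl on a saturated ring carbon. Among the measured compounds shown here, two measured steps bear on this change, both leaving compound 1 by altering the aryl group: an 87-fold lower number from compound 1 to compound 2 (1.94 log units; beyond the scatter) and a 63-fold lower number from compound 1 to compound 3 (1.80 log units; beyond the scatter). For the measured compounds named here, both are large drops in this assay, and the one toward compound 2 likewise adds a second chlorine. A step of comparable size downward is therefore expected for compound 4, a 74-fold lower number from compound 1 to compound 4 (1.87 log units; beyond the scatter). For compound 4 in this assay the estimate is 110 nM, with a range from 20 nM to 600 nM.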

Compound 4, half-maximal effective concentration: 1.91 nM
Compound 4: middle estimate off by 58-fold (1.76 log units), on the high side, and the stated range ends above it.
By their numbers in this assay, from the lowest: compound 4; then compounds 2 and 3 (each within the scatter of the next); then compound 1.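

In this assay, 2,6-dichlorophenyl on the saturated ring carbon gives a 4300-fold lower number from compound 1 to compound 4 (3.63 log units; beyond the scatter), a far larger step than either earlier aryl change from compound 1. It also separates compound 4 from the two lower earlier compounds, with a 68-fold lower number from compound 3 to compound 4 (1.83 log units; beyond the scatter) and a 49-fold lower number from compound 2 to compound 4 (1.69 log units; beyond the scatter). The second of these steps joins two dichlorophenyl groups, so at this position the arrangement of the chlorines on the aryl ring counts, not only their presence, and nothing shown accounts for the size of this gain.

Open, on these data alone, is whether methoxy or nitro groups in place of these chlorines would keep such a low number.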